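Swapping the end of the chain on compound 3

The source may hold more compounds than are shown below. What is called first, only, known or untested is meant among the compounds shown, and "the series" means these compounds.

Three measured compounds share one core and differ in the chain on its aromatic nitrogen: compound 1 `CCn1c(=N)sc2cc(OC(F)(F)F)ccc21`, compound 2 `N=c1sc2cc(OC(F)(F)F)ccc2n1Cc1ccccc1` and compound 3 `N=c1sc2cc(OC(F)(F)F)ccc2n1CCSc1ccccc1`. In a functional assay on the whole organism with Rattus norvegicus as the target (a lower number here means that less compound is needed, a higher number that more compound is needed for the effect), compound 1 gives 5 mg/kg and compound 3 gives 4.5 mg/kg. These two values lie within the scatter of each other, so compound 3 stands level with compound 1. Compound 2 reads > 10 mg/kg, which is a limit of the assay and not a number.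

Compound 4 `CNCCn1c(=N)sc2cc(OC(F)(F)F)ccc21` carries methylamino in place of phenylsulfanyl on a saturated chain carbon, two bonds along the chain from an aromatic nitrogen. Within the data shown here, two measured steps bear on this change. Putting phenylsulfanyl in place of hydrogen on that same carbon gave a 1.1-fold lower number from compound 1 to compound 3 (0.05 log units; within the scatter). The chain still matters, as replacing phenyl with (phenylsulfanyl)methyl gave an at least 2.2-fold lower number from compound 2 to compound 3 (0.34 log units; beyond the scatter). Because of a 1.1-fold lower number from compound 1 to compound 3 (0.05 log units; within the scatter) no step beyond the scatter is expected in this assay for this swap. Among the measured compounds shown here, no measured compound carries methylamino, so the range must stay wide. The expected change is a 1.1-fold higher number from compound 3 to compound 4 (0.05 log units; within the scatter). For compound 4 the estimated value is 5 mg/kg, with an expected range from 1.5 mg/kg to 15 mg/kg.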

Compound 4, dose for half-maximal effect: > 10 mg/kg
Compound 4: a limit, no number (the forecaster's own chance of this, stated with the estimate: 20%); middle value at least 2.0-fold (0.30 log units) from the limit.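

Among these compounds, the swap of phenylsulfanyl for methylamino on a saturated chain carbon, two bonds along the chain from an aromatic nitrogen, is the first change at this place to give a step beyond the scatter in this assay, with an at least 2.2-fold higher number from compound 3 to compound 4 (0.34 log units; beyond the scatter). Set against hydrogen at the same carbon, methylamino gives an at least 2.0-fold higher number from compound 1 to compound 4 (0.30 log units; that floor lies within the scatter), so this comparison alone does not establish a real loss and the clear evidence comes from the swap with phenylsulfanyl. The step from compound 2 to compound 4 cannot be read, and the full size of the step from compound 3 stays unknown, since compound 2 and compound 4 each carry a limit and not a number: the limit of > 10 mg/kg in this assay, at which 2 of the 4 values shown sit.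

Among the compounds shown, no group such as methylsulfanyl, phenylamino or dimethylamino stands at this carbon, so it remains open whether the difference follows the phenyl ring, the sulfur or the amine hydrogen. A longer chain ending in phenylsulfanyl also lies outside the compounds shown, which leaves open how chain length bears on the dose needed.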